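The compounds below may be only part of what the source reports. "The series", "measured", "known", "first", "only" and "open" are said of these compounds alone.

Within the data shown here, compound 1, `CSc1ccc(CSc2nc(-c3ccc(Cl)cc3)c(-c3ccncc3)[nH]2)cc1`, is one of three compounds measured so far in a functional assay (Homo sapiens) for inhibition (a lower number here means a stronger inhibitor, a higher number a weaker inhibitor), where compound 1 gives 2200 nM. Compound 2, `C[S+]([O-])c1ccc(CSc2nc(-c3ccc(Cl)cc3)c(-c3ccncc3)[nH]2)cc1`, differs from compound 1 by a group of 3 heavy atoms (1 carbon, 1 oxygen, 1 sulfur; no ring) in place of a group of 2 heavy atoms (1 carbon, 1 sulfur; no ring), on an aromatic carbon, and in this assay compound 2 gives 320 nM, a step of a 6.9-fold lower number from compound 1 to compound 2 (0.84 log units; beyond the scatter). Compound 3, `CSc1cc(CSc2nc(-c3ccc(F)cc3)c(-c3ccncc3)[nH]2)ccc1O`, has a core that differs from that of compound 1 in more than one place, and the difference between the two cores is not broken down here. In this assay compound 3 gives 280 nM; compound 2 and compound 3 lie within the usual scatter of each other, while both stand well apart from compound 1.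

Compound 4, `C[S+]([O-])c1cc(CSc2nc(-c3ccc(F)cc3)c(-c3ccncc3)[nH]2)ccc1O`, has not yet been measured. It differs from compound 3 by a group of 3 heavy atoms (1 carbon, 1 oxygen, 1 sulfur; no ring) in place of a group of 2 heavy atoms (1 carbon, 1 sulfur; no ring), on an aromatic carbon. This is the same kind of change as that from compound 1 to compound 2, but not the same: in compound 2 the entering group sits para to a large group, whereas in compound 4 it sits ortho to a hydroxy group and meta to a large group. Among the measured compounds shown here, the one earlier instance of this kind of change moved the number by a 6.9-fold lower number from compound 1 to compound 2 (0.84 log units; beyond the scatter). On that single precedent, and with the different surroundings in mind, compound 4 is expected to show a step of a 3.1-fold lower number from compound 3 to compound 4 (0.49 log units; beyond the scatter) in this assay, somewhat smaller than the earlier one. Compound 4 is therefore estimated at 90 nM, most likely between 30 nM and 300 nM.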

Compound 4, half-maximal inhibitory concentration: 2300 nM
For compound 4 the middle estimate is 26-fold (1.41 log units) below the measured one; measured number outside the range, above it.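

In this assay, the exchange of methylsulfanyl for the larger sulfur group did not carry over from one core to the other. It gave an 8.2-fold higher number from compound 3 to compound 4 (0.91 log units; beyond the scatter), so a change that strengthened inhibition on the core of compound 1 weakened it on the core of compound 3, and the two steps differ in direction and by more than their scatter: the same change on two cores in this assay, a 6.9-fold lower number (0.84 log units; beyond the scatter) from compound 1 to compound 2 and an 8.2-fold higher number (0.91 log units; beyond the scatter) from compound 3 to compound 4, 56-fold (1.75 log units) apart, beyond the scatter of two such steps This shows that, across these two cores, the outcome of the change depends on the core it is made on, and that one earlier step does not settle even its direction; it does not show which difference between the cores matters, as the hydroxy group, the place of the sulfur group on its ring and the fluorine in place of chlorine all change together across these two pairs.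

Open, as far as these compounds go, is how the same exchange would behave on a core that carries the fluorine but no hydroxy group, or one in which a methoxy group or an amine stands in place of the hydroxy group. Also open, from the compounds shown here alone, is whether a sulfone, with a second oxygen on the sulfur, would follow compound 2 or compound 4.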